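A few compounds are considered here, and "the series" means these few. Any claim that something is new, unique, unknown or untested is made for them only; others in the source may bear on it.

Of the compounds shown here, two have been measured in a functional assay on the whole organism (stomach) for inhibition, with Canis familiaris (Canis lupus familiaris) as the target, at a dose of 2 mg/kg by the intravenous route; on this read-out lower numbers stand for a weaker effect and higher numbers for a stronger effect at the one dose given. Compound 1 `Cc1nc2c(C[S+]([O-])c3ccccc3)cccn2c1C` gives 0% in this assay. Compound 2 `Cc1nc2c(OCc3ccccc3)cccn2c1CO` gives 80% in this assay, the higher of the two numbers, and its gap to compound 1 lies beyond the usual scatter of repeated measurements. The two structures differ in more than one place, so no single change can be read off from this pair alone.

The step considered here leads from compound 2 to compound 3 `CCc1c(C)nc2c(OCc3ccccc3)cccn12`, a compound not yet measured. The change itself is small: methyl in place of hydroxy on a saturated chain carbon bound to an aromatic carbon. Going by the values given here, no measured pair tells how this particular exchange plays out, so the expectation rests on compound 2 alone and on the smallness of the change. The expected step of a number 25 percentage points lower from compound 2 to compound 3 (beyond the scatter) in this assay points downward, modest in size and possibly beyond the scatter. Compound 3 is therefore expected to give about 55% in this assay, within an estimated range from 20% to 90%.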

Compound 3, a percentage reported as inhibition, in the whole organism at one dose (the size of the read-out at that dose, not a potency): 37%
Estimate against measurement, compound 3: 18 percentage points above, within the range that was stated.
By their numbers in this assay, from the lowest: compound 1; then compound 3; then compound 2.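

Going by these compounds alone, exchanging hydroxymethyl for ethyl gives the first comparison here in which only one place differs, and in this assay it is a large move, a number 43 percentage points lower from compound 2 to compound 3 (beyond the scatter) and so clearly more than repeat-measurement noise. This place, on a saturated chain carbon bound to an aromatic carbon, is therefore sensitive to a one-atom exchange that removes a hydroxy, with its hydrogen-bond donor and acceptor, and brings in a methyl, yet the effect is reduced rather than abolished, since compound 3 still gives 37% at the one dose tested. No supporting measurement accompanies this result that could account for the size of the step.

Going by these compounds, a single pair cannot separate what losing the hydroxy does from what gaining the methyl does, so it remains open which half of the exchange drives the drop. The compounds shown also leave open how a methoxy, an amine, a carboxylic acid or a longer chain such as propyl would fare at this same place on the shared core.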